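A Longer Selenium-Bearing Chain on the Core of Compound 1

A few compounds are considered here, and "the series" means these few. Any claim that something is new, unique, unknown or untested is made for them only; others in the source may bear on it.

Compound 1 `COc1ccc(N(C)c2nc(C)nc3ccccc23)cc1[Se]C` and compound 2 `C[Se]c1ccc(N(C)c2nc(C)nc3ccccc23)cc1Cl` share the same core and differ only in the small groups on one aromatic ring. In a functional assay on MDA-MB-231 cells (Homo sapiens) for inhibition, read by MTT assay, with a stated time of 48 h (on this read-out higher numbers stand for weaker inhibition and lower numbers for stronger inhibition), compound 1 gives 10 nM, while compound 2 gives 7 nM. These two numbers lie within the usual scatter of each other, so neither compound can be called the stronger inhibitor; compound 1 simply holds the higher of the two numbers, with compound 2 nearest to it.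

Compound 3 `COc1ccc(N(C)c2nc(C)nc3ccccc23)cc1OCCCCC[Se]C#N` has not yet been measured. Compared with compound 1 the change is a group of 9 heavy atoms (6 carbon, 1 nitrogen, 1 oxygen, 1 selenium; no ring) in place of a group of 2 heavy atoms (1 carbon, 1 selenium; no ring), on an aromatic carbon. Among the compounds with values here, no pair of measured compounds shows what such a change does in this assay, so any expectation rests on the two values alone. Since compound 1 already reaches 10 nM, a much larger group at this place is expected to cost a little, giving a step of a 2.0-fold higher number from compound 1 to compound 3 (0.30 log units; within the scatter) that sits near the edge of the scatter, with no firm direction beyond that. Compound 3 is therefore estimated at 20 nM, with a likely range from 5 nM to 100 nM.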

Compound 3, half-maximal inhibitory concentration: 4410 nM
Compound 3: middle estimate off by 220-fold (2.34 log units), on the low side; measured number above the stated range.
By their numbers in this assay, from the lowest: compounds 2 and 1 (each within the scatter of the next); then compound 3.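

In this assay, replacing the group of 2 heavy atoms on this aromatic carbon, ortho to a methoxy group, with the group of 9 heavy atoms brings a 440-fold higher number from compound 1 to compound 3 (2.64 log units; beyond the scatter). Within the data shown here, this shows that the position does not tolerate every replacement: the large chain leaves far weaker inhibition, a loss that the earlier compounds, which carry only small groups on this ring, gave no sign of. Nothing measured here gives a reason for this loss.

The change brings in an oxygen on the ring, a long carbon chain and a selenium carrying a nitrile all together, and the compounds shown cannot say which of these parts accounts for the step. A shorter chain with the same selenium and nitrile end, or the same chain ending in an amine or a carboxylic acid, would help separate these parts and show whether anything larger than the small selenium-bearing group can keep a value close to that of compound 1 at 10 nM.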